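A few compounds are considered here, and "the series" means these few. Any claim that something is new, unique, unknown or untested is made for them only; others in the source may bear on it.

Within the data shown here, in an ADME assay on a cell-free system (plasma, Homo sapiens) (on this read-out lower numbers stand for a smaller free fraction and higher numbers for a larger free fraction), compound 2 `CCNC(=O)Nc1nc2cc(-c3ccc(OC)nc3)c(=O)n(C(C)C)c2s1` gives 0.05, the lower of the two numbers so far, while compound 1 `CCNC(=O)Nc1nc2cc(-c3cccnc3)c(=O)n(C(C)C)c2s1` gives 0.21. Compound 3 `CCNC(=O)Nc1nc2cc(-c3cncc(OC)c3)c(=O)n(C(C)C)c2s1` has the same atoms joined differently: 5-methoxypyridin-3-yl in place of 6-methoxypyridin-3-yl on an aromatic carbon. Among the measured compounds shown here, one measured step bears on this change, the modest 4.2-fold lower number from compound 1 to compound 2 (0.62 log units; beyond the scatter), which came with methoxy in place of hydrogen on an aromatic carbon. Compound 3 still carries a methoxy group, so only a small upward change, within the scatter, is expected. The estimated step is a 1.4-fold higher number from compound 2 to compound 3 (0.15 log units; within the scatter). For compound 3 the expected value is 0.07, with an estimated range of 0.03 to 0.15.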

Compound 3, unbound fraction: 0.08
Compound 3: the middle estimate sits 1.1-fold (0.06 log units) below what was measured; the range from low to high includes it.
By their numbers in this assay, from the lowest: compounds 2 and 3 (each within the scatter of the next); then compound 1.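

In this assay, moving the methoxy group from 6-methoxypyridin-3-yl to 5-methoxypyridin-3-yl gives a 1.6-fold higher number from compound 2 to compound 3 (0.20 log units; within the scatter), so these two placements are not told apart. The step of a 2.6-fold lower number from compound 1 to compound 3 (0.42 log units; beyond the scatter) shows that the lower number with methoxy in place of hydrogen is not confined to the placement in compound 2. No measurement at hand gives a reason for either step. The compounds shown leave open whether an amine or a longer ether such as ethoxy at either placement would give a similar number.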